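The source may hold more compounds than are shown below. What is called first, only, known or untested is meant among the compounds shown, and "the series" means these compounds.

Three compounds have been measured in a functional assay on HCT-116 cells (Homo sapiens) for antiproliferative activity, read by MTT assay, with a stated time of 72 h; on this read-out higher numbers stand for weaker inhibition and lower numbers for stronger inhibition:
compound 1 `Cc1ccccc1NC1=C/C(=N/NC(N)=S)C(=O)N=C1Nc1ccccc1C`, which gives 1520 nM;
compound 2 `NC(=S)N/N=C1/C=C(Nc2ccc(Cl)cc2)C(Nc2ccc(Cl)cc2)=NC1=O`, which gives 190 nM;
compound 3 `Cc1ccccc1NC1=C/C(=N/N=C(\N)SCc2ccccc2)C(=O)N=C1Nc1ccccc1C`, which gives 13800 nM.

Compound 2 has the lowest number of the three, and its steps to both others lie beyond the scatter. How the core of compound 2 differs from the core of compound 1 is not broken down here. Compound 3 comes from compound 1 by one change: a group of 11 heavy atoms (8 carbon, 2 nitrogen, 1 sulfur; one six-membered aromatic ring of carbon only) in place of a group of 4 heavy atoms (1 carbon, 2 nitrogen, 1 sulfur; no ring), on a double-bonded nitrogen. That change produced a 9.1-fold higher number from compound 1 to compound 3 (0.96 log units; beyond the scatter), so the incoming group of 11 heavy atoms went with weaker inhibition.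

Compound 4 `N/C(=N\N=C1\C=C(Nc2ccc(Cl)cc2)C(Nc2ccc(Cl)cc2)=NC1=O)SCc1ccccc1` has not yet been measured. It comes from compound 2 by the same change: a group of 11 heavy atoms (8 carbon, 2 nitrogen, 1 sulfur; one six-membered aromatic ring of carbon only) in place of a group of 4 heavy atoms (1 carbon, 2 nitrogen, 1 sulfur; no ring), on a double-bonded nitrogen. The place of the change is described in the same words for both pairs. For compound 4 a step of similar size is expected, estimated as a 7.9-fold higher number from compound 2 to compound 4 (0.90 log units; beyond the scatter), because the same change produced a 9.1-fold higher number from compound 1 to compound 3 (0.96 log units; beyond the scatter). Among the compounds with values here, only one earlier example of this change exists, so the step could turn out smaller or larger. In this assay compound 4 is expected to give 1500 nM, with a likely range from 450 nM to 5000 nM.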

Compound 4, half-maximal inhibitory concentration: 9600 nM
Beside the measured number, compound 4's estimate is 6.4-fold (0.81 log units) below it; the measured number lies above the stated range.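

In this assay, the same change again went with weaker inhibition, this time with a 51-fold higher number from compound 2 to compound 4 (1.70 log units; beyond the scatter). The direction of the change carried over from one core to the other, but its size did not: the same change on two cores in this assay, a 9.1-fold higher number (0.96 log units; beyond the scatter) from compound 1 to compound 3 and a 51-fold higher number (1.70 log units; beyond the scatter) from compound 2 to compound 4, 5.6-fold (0.75 log units) apart, beyond the scatter of two such steps. On these two cores, then, the step seen on one core correctly gave the direction of the step on the other but not a dependable size, and two pairs cannot show why the sizes differ or predict what a further core would do.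

On these data alone, it remains open whether a methyl group, an amine or a carboxylic acid in place of the incoming group of 11 heavy atoms would give a step of a different size on each core. Also open, as far as these compounds go, is which part of the difference between the core of compound 1 and the core of compound 2 goes with the larger step.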